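The source may report more compounds than this note shows. Statements on the series, on what has been measured and on what is new or still open speak of the compounds shown alone.

In an ADME assay (liver) for metabolic stability, with Liver microsome (Homo sapiens) as the target, using microsomes and NADPH, with a stated time of 30 min, tested at 1 uM (on this read-out higher numbers stand for fast clearance and lower numbers for slow clearance), compound 3 (`CC(C)(O)C#Cc1cc(C(O)(C(F)(F)F)C(F)(F)F)cnc1N1CCN(S(=O)(=O)c2ccc(N)nc2)CC1`) is reported only as a limit, < 14 mL.min-1.g-1. Compound 1 (`Nc1ccc(S(=O)(=O)N2CCN(c3ncc(C(O)(C(F)(F)F)C(F)(F)F)cc3Br)CC2)cn1`) is also reported only as a limit, < 14 mL.min-1.g-1. Among the measured compounds shown here, compound 2 (`COCC#Cc1cc(C(O)(C(F)(F)F)C(F)(F)F)cnc1N1CCN(S(=O)(=O)c2ccc(N)nc2)CC1`) gives the only actual number, 15 mL.min-1.g-1. The short series is therefore dominated by the limit of < 14 mL.min-1.g-1 in this assay, at which 2 of the 3 values shown sit.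

The next change leads to compound 4 (`Cn1cc(-c2cc(C(O)(C(F)(F)F)C(F)(F)F)cnc2N2CCN(S(=O)(=O)c3ccc(N)nc3)CC2)cn1`): 1-methyl-1H-pyrazol-4-yl in place of 3-hydroxy-3-methylbut-1-yn-1-yl on an aromatic carbon. It places 1-methyl-1H-pyrazol-4-yl in place of 3-hydroxy-3-methylbut-1-yn-1-yl on an aromatic carbon, ortho to a large group. For the measured compounds named here, no measured step makes this exact exchange. Going by the values given here, the steps that bear on it are an at least 1.0-fold higher number from compound 1 to compound 2 (0.02 log units; that floor lies within the scatter), an at least 1.0-fold lower number from compound 2 to compound 3 (0.02 log units; that floor lies within the scatter) and a step that the two limits leave unreadable from compound 1 to compound 3. None of them shows a readable size beyond the scatter. With compound 2 at 15 mL.min-1.g-1, no step beyond the scatter is expected in this assay, and no direction is favoured. The estimated change is a number no lower from compound 3 to compound 4 (the limit leaves the size open). For compound 4 the expected value is 14 mL.min-1.g-1. The estimated range for compound 4 runs from 8 mL.min-1.g-1 to 28 mL.min-1.g-1, and a report as a limit is quite possible.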

Compound 4, intrinsic clearance in microsomes: 19 mL.min-1.g-1
Compound 4: middle estimate off by 1.4-fold (0.13 log units), on the low side; measured number inside the range.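

With 1-methyl-1H-pyrazol-4-yl, this aromatic carbon now carries a five-membered aromatic ring rather than bromo or an alkynyl chain, and in this assay the exchange with the closest fully measured compound shows a 1.3-fold higher number from compound 2 to compound 4 (0.10 log units; within the scatter). Against the other two compounds, only floors can be read: an at least 1.3-fold higher number from compound 3 to compound 4 (0.13 log units; that floor lies within the scatter), and an at least 1.3-fold higher number from compound 1 to compound 4 (0.13 log units; that floor lies within the scatter). These steps stay open-ended because compound 1 and compound 3 are reported only as limits: the limit of < 14 mL.min-1.g-1 in this assay, at which 2 of the 4 values shown sit.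

As far as these compounds go, it remains open whether any group on this aromatic carbon moves the read-out beyond the scatter, and how large the steps from compound 1 and compound 3 really are. An amine, a carboxylic acid or a longer chain at this place would test how far that tolerance extends.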